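Pyrrolidine for Dimethylamine on the Longer Chain

The compounds below may be only part of what the source reports. "The series", "measured", "known", "first", "only" and "open" are said of these compounds alone.

Compound 3 `CN(C)CCCCOc1c(OCc2ccccc2)cc(O)c2c(=O)cc(-c3ccccc3)oc12` gives 3220 nM in a functional assay on B16 cells (Mus musculus) for cytotoxicity, read by MTT assay, with a stated time of 72 h (a higher number here means a weaker inhibitor, a lower number a stronger inhibitor), the lowest number among the three measured compounds. Compound 1 `CN(C)CCCOc1c(OCc2ccccc2)cc(O)c2c(=O)cc(-c3ccccc3)oc12` gives 5420 nM in this assay, and compound 2 `O=c1cc(-c2ccccc2)oc2c(OCCCN3CCCC3)c(OCc3ccccc3)cc(O)c12` gives 7980 nM in this assay. The step of a 1.7-fold lower number from compound 1 to compound 3 (0.23 log units; within the scatter) keeps compound 3 and compound 1 within the scatter of each other, whereas the step of a 2.5-fold lower number from compound 2 to compound 3 (0.39 log units; beyond the scatter) sets compound 3 apart from compound 2.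

Compound 4 `O=c1cc(-c2ccccc2)oc2c(OCCCCN3CCCC3)c(OCc3ccccc3)cc(O)c12` differs from compound 3 by pyrrolidin-1-yl in place of dimethylamino on a saturated chain carbon, four bonds along the chain from an oxygen on an aromatic ring. Going by the values given here, the one measured step that bears on this exchange is a 1.5-fold higher number from compound 1 to compound 2 (0.17 log units; within the scatter), where the same pair of amines is swapped on the chain of compound 1, three bonds along from the oxygen on the aromatic ring. Among the compounds with values here, only that single step is known, and it is small. On that basis the step from compound 3 to compound 4 is expected to be a 1.3-fold higher number from compound 3 to compound 4 (0.13 log units; within the scatter), a slight rise that stays within the scatter. Compound 4 is therefore estimated at 4300 nM in this assay, with a range from 2200 nM to 8600 nM.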

Compound 4, half-maximal inhibitory concentration: 3210 nM
Estimate against measurement, compound 4: 1.3-fold (0.13 log units) above; low and high end bracket the measured number.
By their numbers in this assay, from the lowest: compounds 4, 3, 1 and 2 (each within the scatter of the next, the first and the last beyond it).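

In this assay, pyrrolidin-1-yl in place of dimethylamino, on a saturated chain carbon four bonds along the chain from an oxygen on an aromatic ring, gives a 1.0-fold lower number from compound 3 to compound 4 (0.00 log units; within the scatter), so this exchange of amines leaves no readable mark at this position, on either chain: the same change on two cores in this assay, a 1.5-fold higher number (0.17 log units; within the scatter) from compound 1 to compound 2 and a 1.0-fold lower number (0.00 log units; within the scatter) from compound 3 to compound 4, 1.5-fold (0.17 log units) apart, within the scatter of two such steps

With pyrrolidine on both sides, (pyrrolidin-1-yl)methyl in place of pyrrolidin-1-yl gives a 2.5-fold lower number from compound 2 to compound 4 (0.40 log units; beyond the scatter), while the step that changes both amine and chain, a 1.7-fold lower number from compound 1 to compound 4 (0.23 log units; within the scatter), does not separate its two compounds. The longer chain thus makes a difference beyond the scatter only in the pyrrolidine pair, and the dimethylamino pair of compound 1 and compound 3 goes against any wider pattern.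

The compounds shown leave open whether a piperidine or a morpholine on the chain would match these two amines. They also leave open whether a still longer chain would carry the numbers any lower.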